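A Longer Amine Tail on the Shared Core

The compounds below may be only part of what the source reports. "The series", "measured", "known", "first", "only" and "open" are said of these compounds alone.

Among the measured compounds shown here, compound 1 `CN(C)CCNc1nc(-c2ccc(NC(=O)Nc3ccc(F)cc3)cc2)nc2c(Cl)c(Cl)sc12` gives 590 nM in a functional assay on NCI-H460 cells (Homo sapiens) for cytotoxicity, read by MTT assay, with a stated time of 72 h (on this read-out higher numbers stand for weaker inhibition and lower numbers for stronger inhibition), the second highest of the three numbers known here. Compound 2 `CN(C)CCNc1nc(-c2ccc(NC(=O)Nc3ccc(Cl)cc3)cc2)nc2c(Cl)c(Cl)sc12` gives 300 nM in this assay, and compound 3 `CN(C)CCNc1nc(-c2ccc(NC(=O)Nc3ccc(Cl)cc3Cl)cc2)nc2c(Cl)c(Cl)sc12` gives 1520 nM. Compound 4 `CCN(CC)CCNc1nc(-c2ccc(NC(=O)Nc3ccc(F)cc3)cc2)nc2c(Cl)c(Cl)sc12` differs from compound 1 by diethylamino in place of dimethylamino on a saturated chain carbon, two bonds along the chain from a nitrogen on an aromatic ring. The measured steps all sit at the aryl urea end of the core: a 2.0-fold lower number from compound 1 to compound 2 (0.29 log units; within the scatter), a 2.6-fold higher number from compound 1 to compound 3 (0.41 log units; beyond the scatter) and a 5.1-fold higher number from compound 2 to compound 3 (0.70 log units; beyond the scatter). None of them changes the amine tail, so none bears on this step. With nothing pointing either way, the number for compound 4 is expected to stay within the scatter of compound 1, a 1.0-fold higher number from compound 1 to compound 4 (0.01 log units; within the scatter). Compound 4 is therefore estimated at 600 nM, with a range from 200 nM to 1800 nM.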

Compound 4, half-maximal inhibitory concentration: 500 nM
The estimate for compound 4 lay 1.2-fold (0.08 log units) above the measured number, and the stated range covers the measured number.
By their numbers in this assay, from the lowest: compounds 2, 4 and 1 (each within the scatter of the next); then compound 3.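

Among the compounds shown here, the earlier compounds varied only the aryl urea end, so this is the first reading at the amine tail: diethylamino in place of dimethylamino gives a 1.2-fold lower number from compound 1 to compound 4 (0.07 log units; within the scatter) in this assay. At this position on the saturated chain, the larger amine therefore leaves the number within the scatter, on the one aryl urea shown. Nothing measured here gives a reason for this result.

As far as these compounds go, whether a longer chain or a carboxylic acid in place of the amine would also keep the number there remains open. So does whether diethylamino would behave the same way alongside the aryl urea of compound 2 or compound 3.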